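The source may hold more compounds than are shown below. What is called first, only, known or untested is meant among the compounds shown, and "the series" means these compounds.

In a functional assay on Jurkat cells (Homo sapiens) for cytotoxicity, with a stated time of 72 h (a higher number here means that more compound is needed for the effect, a lower number that less compound is needed), compound 1 (`CCOC(=O)/C(C)=C/c1cc(/C=C/[C@](C)(/C=C/c2ccc(OC)cc2)CCC=C(C)C)ccc1O`) gives > 49000 nM, which is a limit of the assay and not a number. Compound 2 (`COc1ccc(/C=C/[C@@](C)(/C=C/c2ccc(O)c(/C=C/C(=O)c3ccccc3)c2)CCC=C(C)C)cc1`) gives > 49000 nM, which is also a limit. Compound 2 therefore has no exact position on the scale, and the picture so far is the limit of > 49000 nM in this assay, at which 2 of the 2 values shown sit. Within the data shown here, the only measured step, a step that the two limits leave unreadable from compound 1 to compound 2, has no size that can be carried forward.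

Compound 3 (`COc1ccc(/C=C/[C@@](C)(/C=C/c2ccc(O)cc2)CCC=C(C)C)cc1`) departs from compound 2 through (hydrogen in place of 2-benzoylethenyl on an aromatic carbon), so that hydrogen stands in place of 2-benzoylethenyl, ortho to a hydroxy group. Among the measured compounds shown here, no measured step removes this group outright, so the data set no size for this change. The sole anchor for an expectation is that compound 2 gives > 49000 nM, a limit. A reading at the same limit is therefore quite likely, and any number that does appear is expected to lie only modestly lower in this assay. The expected step, an at least 1.4-fold lower number from compound 2 to compound 3 (0.14 log units; that floor lies within the scatter), is thus an uncertain estimate pointing toward less compound being needed. For compound 3 the estimate is 35000 nM, with an expected range from 12000 nM to 49000 nM.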

Compound 3, half-maximal effective concentration: > 49000 nM
Compound 3 gave a limit, no number; the forecaster's own chance of this, stated with the estimate: 60%; middle value at least 1.4-fold (0.14 log units) away from the limit.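

In this assay compound 3 gives > 49000 nM, again a limit and not a number. The steps to it from compound 1 and compound 2 therefore cannot be read, and the picture remains: the limit of > 49000 nM in this assay, at which 3 of the 3 values shown sit. The compounds shown leave open what size, or even what direction, any of these changes on the aromatic carbon has.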